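Swapping Chloro for Amino in Two Related Compounds

A few compounds are considered here, and "the series" means these few. Any claim that something is new, unique, unknown or untested is made for them only; others in the source may bear on it.

Compound 1, compound 2 and compound 3 have been measured in a functional assay on NCI/ADR-RES cells (Homo sapiens) for cytotoxicity, read by sulforhodamine B assay, with a stated time of 48 h; on this read-out lower numbers stand for stronger inhibition of growth and higher numbers for weaker inhibition of growth. Compound 1 `ClCc1ccccc1Cn1cnc2c(Cl)nc(Cl)nc21` gives 1510 nM in this assay. Compound 2 `ClCc1cccc(Cn2cnc3c(Cl)nc(Cl)nc32)c1` is built from the same atoms joined differently; how its core differs from the core of compound 1 is not broken down here. In this assay, for the measured compounds named here, compound 2 gives 2390 nM, a number that lies within the usual scatter of the one for compound 1, so the two cannot be told apart on this read-out. Compound 3 `Nc1nc(Cl)c2ncn(Cc3ccccc3CCl)c2n1` arises from compound 1 by a single change: amino in place of chloro on an aromatic carbon. In this assay compound 3 gives 4470 nM, and the step of a 3.0-fold higher number from compound 1 to compound 3 (0.47 log units; beyond the scatter) lies beyond the scatter, so compound 3 inhibits growth less strongly than compound 1.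

Compound 4 `Nc1nc(Cl)c2ncn(Cc3cccc(CCl)c3)c2n1` has not yet been measured. It arises from compound 2 by the same change, (amino in place of chloro on an aromatic carbon), and the surroundings of the place are described in the same words as for the earlier pair. Going by the values given here, only one measured example of this change exists, so any expectation rests on that example alone. Among the compounds with values here, for compound 4 the expected step is a 2.9-fold higher number from compound 2 to compound 4 (0.47 log units; beyond the scatter), a size taken from a 3.0-fold higher number from compound 1 to compound 3 (0.47 log units; beyond the scatter) as the sole record of this change. Compound 4 is therefore estimated at 7000 nM in this assay, with a likely range from 3500 nM to 14000 nM.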

Compound 4, concentration for 50% growth inhibition: 4890 nM
Estimate against measurement, compound 4: 1.4-fold (0.16 log units) above; the measured number falls inside the stated range.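

In this assay, putting amino in place of chloro on an aromatic carbon again weakens the inhibition of growth, and on the core of compound 2 the change gives a 2.0-fold higher number from compound 2 to compound 4 (0.31 log units; beyond the scatter). Both pairs move in the same direction, and the sizes of the two steps cannot be told apart: the same change on two cores in this assay, a 3.0-fold higher number (0.47 log units; beyond the scatter) from compound 1 to compound 3 and a 2.0-fold higher number (0.31 log units; beyond the scatter) from compound 2 to compound 4, 1.4-fold (0.16 log units) apart, within the scatter of two such steps. Within these four compounds the change therefore carries over from one core to the other with a similar effect, but two pairs are a small sample, and they show neither why the number rises nor whether the same would hold on any other core.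

The compounds shown leave open whether another group at the same place, such as methylamino, methoxy or a plain hydrogen, would keep the growth inhibition seen with chloro or lose it as amino does. They also leave open whether the step stays the same when the chloromethyl group gives way to a hydroxymethyl group or a longer chain.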